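Returning from Tetrazole to Carboxylic Acid: Expected Affinity Change

This account rests on a few compounds, and the source may have more. Where it says the series, first, only, none or still open, it means among the compounds named here.

Compound 1, `O=C(O)CC1CCCC1Cc1ccc(OCc2ccc3ccccc3n2)cc1`, in an assay on membranes from lung (Cavia porcellus) for binding affinity to cysteinyl leukotriene receptor (Homo sapiens); on this read-out lower numbers stand for stronger inhibition and higher numbers for weaker inhibition: 100 nM
Compound 2, `O=C(O)CCC(Cc1ccc(OCc2ccc3ccccc3n2)cc1)c1ccccc1`, in this assay: 31 nM
Compound 3, `CC(CCc1nnn[nH]1)Cc1ccc(OCc2ccc3ccccc3n2)cc1`, in this assay: 12 nM

Compound 3 stands lowest of the three numbers; compound 2 and compound 1 both give higher values. Compound 4, `O=C(O)CCCCc1ccc(OCc2ccc3ccccc3n2)cc1`, differs from compound 3 in one place: 3-carboxypropyl in place of 3-(1H-tetrazol-5-yl)-1-methylpropyl on a saturated chain carbon bound to an aromatic carbon. Within the data shown here, the only measured step that bears on this change runs the other way: an 8.3-fold lower number from compound 1 to compound 3 (0.92 log units; beyond the scatter). There, a carboxylic acid group gave way to a tetrazole and the number fell. Putting an acid back, now on a shorter unbranched chain, is expected to raise the number again. Compound 4 is therefore expected at 150 nM, with a range of 40 nM to 600 nM, meaning an estimated step of a 13-fold higher number from compound 3 to compound 4 (1.10 log units; beyond the scatter).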

Compound 4, inhibition constant: 110 nM
Beside the measured number, compound 4's estimate is 1.4-fold (0.13 log units) above it, within the range that was stated.
By their numbers in this assay, from the lowest: compound 3; then compound 2; then compounds 1 and 4 (each within the scatter of the next).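

In this assay, 3-carboxypropyl in place of 3-(1H-tetrazol-5-yl)-1-methylpropyl gives a 9.2-fold higher number from compound 3 to compound 4 (0.96 log units; beyond the scatter) on the same core, so the advantage of compound 3 now also holds against a plain unbranched acid. Among the acids, removing the phenyl gives a 3.5-fold higher number from compound 2 to compound 4 (0.55 log units; beyond the scatter), so that group goes with the lower number. The cyclopentyl ring gains nothing over the open chain, with a 1.1-fold higher number from compound 1 to compound 4 (0.04 log units; within the scatter).

As far as these compounds go, the tetrazole and the methyl branch change together, so their separate shares, and the effect of a sulfonic acid or a longer chain here, stay open. Nothing shown explains these steps.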